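The source may hold more compounds than are shown below. What is called first, only, known or untested is meant among the compounds shown, and "the series" means these compounds.

Notes on the series in an ADME assay on HepG2 cells (Homo sapiens) for cytotoxicity, read by trypan blue exclusion, with a stated time of 48 h, in the presence of a further agent that is not named here; on this read-out lower numbers stand for higher toxicity in this test and higher numbers for lower toxicity in this test. Compound 1 `COc1cc(NC(=O)COc2cc(C)nc3ccc(OC)cc23)cc(OC)c1` reaches in this assay only the limit > 131000 nM, which is a boundary of the assay and not a number. Compound 2 `COc1ccc2nc(C)cc(OCC(=O)Nc3cccc(Br)c3)c2c1` likewise reaches in this assay only the limit > 125000 nM, again a boundary and not a number. Where compound 2 stands is thus given by the limit of > 125000 nM in this assay, at which 1 of the 2 values shown sits, and the other entry is equally a boundary, (the limit of > 131000 nM in this assay, at which 1 of the 2 values shown sits); neither compound shows toxicity within the tested range, and no step between measured compounds can be sized.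

Compound 3 `C#CCNC(=O)COc1cc(C)nc2ccc(OC)cc12` differs from compound 2 by propargyl in place of 3-bromophenyl on an amide-type nitrogen. Going by the values given here, with both known values sitting at boundaries there is no measured step to build on; the expectation is that this change leaves the read-out where compound 2 already sits, so the step that the limit leaves unreadable from compound 2 to compound 3 is expected to be small, without a clear direction and not beyond the scatter. On that basis compound 3 is estimated at 150000 nM, with a range from 60000 nM to 400000 nM, and most likely once more a boundary rather than a number in this assay.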

Compound 3, half-maximal cytotoxic concentration: > 176000 nM
Compound 3: only a limit was reported; the forecaster's own chance of this, stated with the estimate: 75%; middle value at least 1.1-fold (0.06 log units) away from the limit.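

In this assay compound 3 also gives only a limit, as compound 2 does, so no step between compound 2 and compound 3 can be read: the limit of > 176000 nM in this assay, at which 1 of the 3 values shown sits.

The compounds shown leave open where the half-maximal cytotoxic concentration of compound 1, compound 2 or compound 3 lies, and what propargyl in place of 3-bromophenyl changes.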